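The source may hold more compounds than are shown below. What is called first, only, known or untested is meant among the compounds shown, and "the series" means these compounds.

Compound 1 `CN1CCCN(CC(=O)NC2(c3ccc(Cl)c(Cl)c3)C(=O)Nc3cc(Cl)cc(Cl)c32)CC1`: 64 nM
Compound 2 `CN(C)C1CCN(CC(=O)NC2(c3ccc(Cl)c(Cl)c3)C(=O)Nc3cc(Cl)cc(Cl)c32)CC1`: 239 nM
Compound 3 `Cc1ccc2c(c1Cl)C(NC(=O)CN1CCN(C)CC1)(c1ccc(Cl)cc1)C(=O)N2`: 1160 nM

In an in vitro functional assay on CHO-CREluc cells for antagonist activity at growth hormone secretagogue receptor type 1 (Homo sapiens), read by a luciferase reporter, with a stated time of 4 h (on this read-out lower numbers stand for stronger inhibition and higher numbers for weaker inhibition), compound 2 stands second of the three numbers: compound 1 gives the lowest, and compound 3, built on a different core, gives the highest. Compound 4 `CCN1CCN(CC(=O)NC2(c3ccc(Cl)c(Cl)c3)C(=O)Nc3cc(Cl)cc(Cl)c32)CC1` differs from compound 2 by 4-ethylpiperazin-1-yl in place of 4-(dimethylamino)piperidin-1-yl on a saturated chain carbon bound to a carbonyl carbon. Among the measured compounds shown here, only one measured step touches this place, and it is modest: a 3.7-fold higher number from compound 1 to compound 2 (0.57 log units; beyond the scatter). The new ring brings back two hetero atoms, closer to the ring of compound 1, so a step in the opposite direction is expected, and a 2.4-fold lower number from compound 2 to compound 4 (0.38 log units; beyond the scatter) is the estimated size. Compound 4 is therefore expected at 100 nM, with a range from 30 nM to 350 nM.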

Compound 4, half-maximal inhibitory concentration: 7 nM
Compound 4: the middle estimate sits 14-fold (1.15 log units) above what was measured, and the stated range ends above it.
By their numbers in this assay, from the lowest: compound 4; then compound 1; then compound 2; then compound 3.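

In this assay, among the compounds shown here, this place proves far more sensitive than the earlier compounds suggested, with 4-ethylpiperazin-1-yl giving a 34-fold lower number from compound 2 to compound 4 (1.53 log units; beyond the scatter) and, against the 4-methyl-1,4-diazepan-1-yl ring, a 9.1-fold lower number from compound 1 to compound 4 (0.96 log units; beyond the scatter) on the same core. The large step comes even though the hydrogen-bond donor and acceptor counts do not change. Nothing measured here explains the gain.

Still open, going by these compounds, is whether the piperazine ring or its ethyl group matters more. A 4-methylpiperazin-1-yl or 4-isopropylpiperazin-1-yl group on the core of compound 4 would separate the two.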